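A Methoxy Group Added to Compound 2

The source may report more compounds than this note shows. Statements on the series, on what has been measured and on what is new or still open speak of the compounds shown alone.

Among the compounds with values here, in a functional assay on MCF7 cells (Homo sapiens) for cytotoxicity, read by MTT assay, with a stated time of 48 h (a lower number here means a stronger inhibitor, a higher number a weaker inhibitor), compound 1 (`CCN(CC)C(=S)SC(CC(=O)c1ccccc1)c1ccccc1`) gives 17000 nM and compound 2 (`CCN(CC)C(=S)SC(CC(=O)c1ccc(Br)cc1)c1ccccc1`) gives 5000 nM as the lower of the two numbers so far. Within the data shown here, the one measured step is a 3.4-fold lower number from compound 1 to compound 2 (0.53 log units; beyond the scatter) and comes with bromo in place of hydrogen on an aromatic carbon. Compound 3 (`CCN(CC)C(=S)SC(CC(=O)c1ccc(Br)cc1)c1ccc(OC)cc1`) differs from compound 2 by methoxy in place of hydrogen on an aromatic carbon with methoxy in place of hydrogen on an aromatic carbon, para to a large group. Among the measured compounds shown here, the step of a 3.4-fold lower number from compound 1 to compound 2 (0.53 log units; beyond the scatter) is the only guide and it concerns a different group. For the measured compounds named here, no step for methoxy has been measured, so only a weak expectation is possible. In this assay the estimated change is a 1.1-fold lower number from compound 2 to compound 3 (0.05 log units; within the scatter) and no firm direction can be given, with a step within the scatter expected. For compound 3 the estimate is 4500 nM with 1500 nM to 13000 nM as the expected range.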

Compound 3, half-maximal inhibitory concentration: 5000 nM
Beside the measured number, compound 3's estimate is 1.1-fold (0.05 log units) below it; the measured number falls inside the stated range.
By their numbers in this assay, from the lowest: compounds 2 and 3 (each within the scatter of the next); then compound 1.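

In this assay, phenyl to 4-methoxyphenyl, with methoxy in place of hydrogen on an aromatic carbon, para to a large group, gives no change at the digits printed from compound 2 to compound 3 (within the scatter). So this position, on a six-membered aromatic ring of carbon only, can carry methoxy with no visible cost or gain in this read-out, whereas the only earlier change, bromo in place of hydrogen, gave a 3.4-fold lower number from compound 1 to compound 2 (0.53 log units; beyond the scatter). Nothing available explains why the methoxy change leaves the number where it stands.

The compounds shown leave open whether an amine or a carboxylic acid at this same place would move the number, since methoxy is the only group seen there. They also leave open whether methoxy would behave the same way on the core of compound 1, which has no bromo.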